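A few compounds are considered here, and "the series" means these few. Any claim that something is new, unique, unknown or untested is made for them only; others in the source may bear on it.

Measured so far in an assay for inhibition of Polyunsaturated fatty acid 5-lipoxygenase (Homo sapiens), read by spectrophotometry, tested at 20 uM; a higher number here means more inhibition at the concentration tested (going by the name of the read-out), a lower number less inhibition:
Compound 1 `CN(C)c1ccc(/C=C/C=C/C(=O)N2CCCCC2)cc1` gives 13.4%
Compound 2 `CSc1ccc(/C=C/C=C/C(=O)N2CCCCC2)cc1` gives 11.8%

Compound 2 stands at the lower of the two numbers shown; its nearest neighbour is compound 1, which lies higher by an amount within the scatter, so the two cannot be told apart on these readings. Compound 3 `O=C(/C=C/C=C/c1ccc(Cl)cc1)N1CCCCC1` differs from compound 2 in one place: chloro in place of methylsulfanyl on an aromatic carbon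

Within the data shown here, only one measured step speaks to this change, and only loosely: a number 1.6 percentage points lower from compound 1 to compound 2 (within the scatter) exchanged one group for another on an aromatic carbon of the same six-membered aromatic ring of carbon only, and that exchange left the inhibition where it was. Among the measured compounds shown here, the change to compound 3 is again an exchange of a single group at that kind of position, with a smaller group entering, but no measured pair shows what a chloro group does there. For the measured compounds named here, on the single step available, the expected step of a number 0.2 percentage points higher from compound 2 to compound 3 (within the scatter) is none beyond the scatter. Compound 3 is therefore estimated to give 12% in this assay, with a plausible range from 3% to 24%.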

Compound 3, a percentage reported as inhibition, at one concentration (the size of the read-out at that concentration, not a potency): 14.5%
Estimate against measurement, compound 3: 2.5 percentage points below; measured number inside the range.
By their numbers in this assay, from the lowest: compounds 2, 1 and 3 (each within the scatter of the next).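

In this assay, chloro in place of methylsulfanyl on an aromatic carbon gives a number 2.7 percentage points higher from compound 2 to compound 3 (within the scatter), and chloro in place of dimethylamino on an aromatic carbon gives a number 1.1 percentage points higher from compound 1 to compound 3 (within the scatter). The earlier pair covered only methylsulfanyl and dimethylamino; now a third group at this position, para to a large group, also gives a reading that cannot be told apart, even though chloro has no hydrogen-bond acceptor and a single heavy atom. Across these three compounds, the exchanges shown at this position leave the inhibition at the concentration tested unresolved, and no independent measurement is available to account for that result.

What these compounds leave open is whether any group at this position can shift the reading beyond the scatter, for example a carboxylic acid, a hydroxyl group or a longer chain. They also leave open whether a change elsewhere on the shared core would matter more than any exchange at this aromatic carbon, and, as each reading comes from one concentration, how these compounds compare in potency.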